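The source may report more compounds than this note shows. Statements on the series, on what has been measured and on what is new or still open speak of the compounds shown alone.

Measured compounds:
compound 1 `O=C(/C=C/c1ccc([N+](=O)[O-])cc1)Nc1cc2c(Nc3ccc(F)c(Cl)c3)ncnc2cc1O[C@H]1CCOC1` — 27400 nM
compound 2 `COc1ccc(/C=C/C(=O)Nc2cc3c(Nc4ccc(F)c(Cl)c4)ncnc3cc2OC)cc1` — "not determined" (no result reported)
compound 3 `COc1ccc(/C=C/C(=O)Nc2cc3c(Nc4ccc(F)c(Cl)c4)ncnc3cc2O[C@H]2CCOC2)c(OC)c1OC` — 4830 nM

In a functional assay on HeLa cells (Homo sapiens) for cytotoxicity, read by MTT assay, with a stated time of 72 h (on this read-out lower numbers stand for stronger inhibition and higher numbers for weaker inhibition), compound 1 stands at the highest of the two numbers, and its nearest neighbour is compound 3, reached by a 5.7-fold lower number from compound 1 to compound 3 (0.75 log units; beyond the scatter). Among the measured compounds shown here, compound 4 `COc1cc(/C=C/C(=O)Nc2cc3c(Nc4ccc(F)c(Cl)c4)ncnc3cc2O[C@H]2CCOC2)cc(OC)c1O` changes compound 1 differently: 4-hydroxy-3,5-dimethoxyphenyl in place of 4-nitrophenyl on a double-bonded chain carbon bound to a double-bonded chain carbon The only step that bears on this is the one from compound 1 to compound 3, where a 4-nitrophenyl was also replaced by a methoxy-bearing aryl group and the number fell by a modest but real margin. For the measured compounds named here, a similar move downward is therefore expected for compound 4, estimated as a 4.2-fold lower number from compound 1 to compound 4 (0.62 log units; beyond the scatter), with the single hydroxy group leaving the outcome uncertain. The expected value for compound 4 in this assay is 6500 nM, within a range of 2000 nM to 20000 nM.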

Compound 4, half-maximal inhibitory concentration: 27400 nM
Estimate against measurement, compound 4: 4.2-fold (0.62 log units) below; the whole stated range lies below it.
By their numbers in this assay, from the lowest: compound 3; then compounds 1 and 4 (each within the scatter of the next).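

In this assay, 4-hydroxy-3,5-dimethoxyphenyl in place of 4-nitrophenyl gives no change at the digits printed from compound 1 to compound 4 (within the scatter) and so shows that methoxy groups on this ring do not by themselves lower the number. The same group in place of 2,3,4-trimethoxyphenyl gives a 5.7-fold higher number from compound 3 to compound 4 (0.75 log units; beyond the scatter) and so ties the lower number to the group in compound 3, not to every methoxy-bearing aryl group here. No measurement explains this gap.

On these data alone, whether the hydroxy group of compound 4 or the arrangement of its methoxy groups sets it apart from compound 3 stays open. As far as these compounds go, how a dimethylamino group or a carboxylic acid on this ring would behave is also open.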